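Swapping a Quinoline for a Pyrazole in an Inactive Series

The source may report more compounds than this note shows. Statements on the series, on what has been measured and on what is new or still open speak of the compounds shown alone.

The shared core of this small set carries an amide on a bicyclic scaffold; compound 1 is `CCCn1c(NC(=O)c2cc(C)nn2CC)nc2cccc(OC)c21` and compound 2 is `CCCn1c(NC(=O)c2ccc3ccccc3n2)nc2cc(C(N)=O)cc(OC)c21`. Both were tested in an assay for activation of interferon regulatory factor 3 (Homo sapiens), read by a luciferase reporter, with a stated time of 20 h; on this read-out higher numbers stand for an effect only at larger amounts of compound and lower numbers for an effect already at smaller amounts. Compound 1 reached only the limit of the assay, giving > 100000 nM. Compound 2 likewise reached only the limit, giving > 100000 nM. Where compound 2 stands is therefore not a number but a boundary, as summed up by the limit of > 100000 nM in this assay, at which 2 of the 2 values shown sit; no effect was seen within the range that was tested.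

Compound 3 is `CCCn1c(NC(=O)c2ccnn2CC)nc2cc(C(N)=O)cc(OC)c21`. It differs from compound 2 in one place: 1-ethyl-1H-pyrazol-5-yl in place of quinolin-2-yl on a carbonyl carbon. Among the compounds with values here, compound 1 already carries a group of the kind that enters here and sits at the same limit, so no measured step exists on which to build a direction. In this assay the step is expected to be small, a number no higher from compound 2 to compound 3 (the limit leaves the size open), not beyond the usual scatter. Compound 3 is expected to give about 100000 nM, in a range from 30000 nM to 300000 nM, most likely again reported only as a limit.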

Compound 3, half-maximal effective concentration: > 100000 nM
Compound 3 ended at the assay's limit; the forecaster's own chance of this, stated with the estimate: 85%; the middle value sits exactly at the limit.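

In this assay compound 2 and compound 3 both end at a limit rather than a number, so no step can be read from the swap of quinolin-2-yl for 1-ethyl-1H-pyrazol-5-yl: the limit of > 100000 nM in this assay, at which 3 of the 3 values shown sit.

The compounds shown leave open whether either group on the carbonyl carbon matters, and what, if anything, would give a measurable effect on the shared core.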